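The source may hold more compounds than are shown below. What is called first, only, known or untested is meant among the compounds shown, and "the series" means these compounds.

Measured so far in a functional assay on Shh Light II cells (Mus musculus) for inhibition, read by a luciferase reporter; on this read-out lower numbers stand for stronger inhibition and higher numbers for weaker inhibition:
- compound 1 `O=C(Nc1ccccc1Cl)N1CCC(c2nc(-c3ccc4ccccc4n3)no2)CC1` gives 510 nM
- compound 2 `O=C(OC1CCCCC1)N1CCC(c2nc(-c3ccc4ccccc4n3)no2)CC1` gives 580 nM

Within the data shown here, compound 1 holds the lowest of the two numbers, but its only neighbour, compound 2, sits at a 1.1-fold higher number from compound 1 to compound 2 (0.06 log units; within the scatter), so the two values cannot be told apart. Compound 3 `O=C(OCc1ccccc1)N1CCC(c2nc(-c3ccc4ccccc4n3)no2)CC1` has not been measured. Relative to compound 1 the change is benzyloxy in place of (2-chlorophenyl)amino on a carbonyl carbon. Among the measured compounds shown here, the one measured step that bears on this is the exchange at the same carbonyl carbon from compound 1 to compound 2, cyclohexyloxy in place of (2-chlorophenyl)amino, which read a 1.1-fold higher number from compound 1 to compound 2 (0.06 log units; within the scatter). Compound 3 makes the same kind of exchange at the same carbonyl carbon, with benzyloxy rather than cyclohexyloxy as the group that enters, and the shared core is untouched. For the measured compounds named here, the single precedent says such a replacement moves the number no further than the scatter. Going by the values given here, a benzyloxy group itself has no measured precedent, so the range is kept wide. Compound 3 is therefore expected near 600 nM, roughly 250 nM to 1500 nM, a step of a 1.2-fold higher number from compound 1 to compound 3 (0.07 log units; within the scatter) that is estimated to stay within the scatter.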

Compound 3, half-maximal inhibitory concentration: > 2500 nM
Compound 3 was reported as a limit; the forecaster's own chance of this, stated with the estimate: 3%; at least 4.1-fold (0.61 log units) between middle value and limit.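

In this assay compound 3 is reported only as a limit, not as a number: the limit of > 2500 nM in this assay, at which 1 of the 3 values shown sits.

The earlier exchange on this carbonyl carbon stayed within the scatter (a 1.1-fold higher number from compound 1 to compound 2 (0.06 log units; within the scatter)), whereas benzyloxy brings an at least 4.9-fold higher number from compound 1 to compound 3 (0.69 log units; beyond the scatter), so this place does respond to the group it carries. The oxygen link alone does not account for the loss, since benzyl in place of cyclohexyl on the same oxygen brings an at least 4.3-fold higher number from compound 2 to compound 3 (0.63 log units; beyond the scatter), and the six-membered aromatic ring alone does not account for it either, since compound 1 carries one too.

On these data alone, what remains open is whether the loss belongs to the benzyl group as a whole or to the way its ring is attached to the oxygen. A phenoxy group, a benzylamino group or a cyclohexylmethoxy group on the same carbonyl carbon would separate these readings, and a cyclohexylamino group would show whether the amide hydrogen matters when no aromatic ring is present.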